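Chain extension on the acetamide of compound 1

A few compounds are considered here, and "the series" means these few. Any claim that something is new, unique, unknown or untested is made for them only; others in the source may bear on it.

Within the data shown here, compound 1 `CC(=O)Nc1c(C(O)(C(F)(F)F)C(F)(F)F)ccc2ccccc12` gives 18 nM in an assay on LtK cells with ATP-sensitive inward rectifier potassium channel 11 (Homo sapiens) as the target (a lower number here means that less compound is needed, a higher number that more compound is needed for the effect), the lowest of the three numbers measured so far. Compound 3 `CCCC(=O)Nc1c(C(O)(C(F)(F)F)C(F)(F)F)ccc2ccccc12` gives 131 nM and compound 2 `CC(C)C(=O)Nc1c(C(O)(C(F)(F)F)C(F)(F)F)ccc2ccccc12` gives 6630 nM. The step of a 7.3-fold higher number from compound 1 to compound 3 (0.86 log units; beyond the scatter) shows that a longer chain on the carbonyl carbon already moves the number upward, while a 370-fold higher number from compound 1 to compound 2 (2.57 log units; beyond the scatter) shows a much larger loss when the chain branches at the carbon bound to the carbonyl carbon; a 51-fold lower number from compound 2 to compound 3 (1.70 log units; beyond the scatter) separates these two cases.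

Compound 4 `CC(C)CCC(=O)Nc1c(C(O)(C(F)(F)F)C(F)(F)F)ccc2ccccc12` has not been measured in this assay. It differs from compound 1 by isobutyl in place of hydrogen on a saturated chain carbon bound to a carbonyl carbon. The chain here is longer than in compound 3, and its branching is not at the carbon bound to the carbonyl carbon, unlike compound 2. The most relevant measured step is therefore a 7.3-fold higher number from compound 1 to compound 3 (0.86 log units; beyond the scatter), both being additions of unbranched carbons at that carbon, while compound 2 with 6630 nM marks the unfavourable end. A step in the same upward direction, larger than that to compound 3 but well short of that to compound 2, is expected. For compound 4 the expected value is 500 nM, with a range of 100 nM to 3000 nM, corresponding to an estimated step of a 28-fold higher number from compound 1 to compound 4 (1.44 log units; beyond the scatter).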

Compound 4, half-maximal effective concentration: 49 nM
Beside the measured number, compound 4's estimate is 10-fold (1.01 log units) above it; the whole stated range lies above it.
By their numbers in this assay, from the lowest: compound 1; then compound 4; then compound 3; then compound 2.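

In this assay, adding carbons to the chain on the carbonyl carbon does not raise the number steadily: a 2.7-fold lower number from compound 3 to compound 4 (0.43 log units; beyond the scatter), so the longer isopentyl chain gives a lower number than the propyl chain, although a 2.7-fold higher number from compound 1 to compound 4 (0.43 log units; beyond the scatter) leaves compound 1 the lowest of the four. Branching as such does not bring the large loss seen with isopropyl on the carbonyl carbon, since isopentyl also carries a branch, further out along the chain, and a 140-fold lower number from compound 2 to compound 4 (2.13 log units; beyond the scatter); among these compounds, the large loss appears only in compound 2, where the branch sits at the carbon bound to the carbonyl carbon. No supporting data are available to explain either the recovery with isopentyl or the loss with isopropyl.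

Going by these compounds, it remains open whether the recovery belongs to the terminal branch or to chain length alone, which an unbranched pentyl chain on the carbonyl carbon would separate. On these data alone, the response to a still longer chain, or to a chain ending in an amine or a carboxylic acid, also remains unknown.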